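This account rests on a few compounds, and the source may have more. Where it says the series, first, only, none or still open, it means among the compounds named here.

Two compounds that share one core have been followed in an ADME assay on the whole organism for metabolic stability, with Canis familiaris (Canis lupus familiaris) as the target; on this read-out lower numbers stand for a shorter-lived compound and higher numbers for a longer-lived compound. Compound 1 (`O=C(Nc1cccnc1-c1ccsc1)N1CCN2C(=O)N([C@H]3C[C@@H]3c3ccccc3)C(=O)[C@@H]2C1`) gives 3.1 h, and compound 2 (`CS(=O)(=O)c1cc(Cl)c(NC(=O)N2CCN3C(=O)N([C@H]4C[C@@H]4c4ccccc4)C(=O)[C@@H]3C2)c(Cl)c1`) gives 1 h. Compound 1 therefore holds the higher of the two numbers. The gap that separates it from compound 2 is larger than the usual scatter of repeated measurements.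

The next compound is compound 3 (`O=C(Nc1cccc(Cl)c1Cl)N1CCN2C(=O)N([C@H]3C[C@@H]3c3ccccc3)C(=O)[C@@H]2C1`). It keeps the shared core and changes one group on an amide-type nitrogen, with 2,3-dichlorophenyl in place of 2-(thiophen-3-yl)pyridin-3-yl (2,3-dichlorophenyl in place of 2-(thiophen-3-yl)pyridin-3-yl on an amide-type nitrogen). For the measured compounds named here, no two measured compounds differ in just one place, so the data offer no direct guide to the size of this step.

Going by the values given here, the only hint comes from compound 2, which also carries chlorine on its aromatic ring and gives 1 h. It differs from compound 3 in more than one respect, so the hint is weak. A modest fall is expected, one that may well stay within the scatter. The expected change is a 1.6-fold lower number from compound 1 to compound 3 (0.19 log units; within the scatter). For compound 3 the estimate is 2 h, with an expected range from 0.9 h to 4.5 h.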

Compound 3, half-life: 10 h
Compound 3: the middle estimate sits 5.0-fold (0.70 log units) below what was measured; measured number outside the range, above it.
By their numbers in this assay, from the lowest: compound 2; then compound 1; then compound 3.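

Placing 2,3-dichlorophenyl on the amide-type nitrogen, where compound 1 has 2-(thiophen-3-yl)pyridin-3-yl, gives the first comparison in this assay in which only one place differs, and it shows a 3.2-fold higher number from compound 1 to compound 3 (0.51 log units; beyond the scatter). This position therefore matters for the read-out, as the number responds to the group attached there, and a single carbon-only aromatic ring bearing two chlorine atoms gives the longer half-life of this pair, replacing two aromatic rings that each contain a hetero atom. No supporting measurement is available to explain this rise.

This single step changes the ring count, the hetero atoms and the chlorine atoms together, so it cannot show which of these differences accounts for the rise. Going by these compounds, a plain phenyl group, a 3-chlorophenyl group or a 2-methoxyphenyl group in this place would help separate those differences, and whether the same swap would have a similar effect on a different core or in another species remains open.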